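Swapping a bromophenyl for a pyridyl: expected solubility

The compounds below may be only part of what the source reports. "The series", "measured", "known", "first", "only" and "open" are said of these compounds alone.

Compounds measured in a physicochemical assay for solubility, read by nephelometry, in phosphate buffer, measured as kinetic solubility, at pH 6.5; a lower number here means a less soluble compound, a higher number a more soluble compound:
Compound 1, `CCOC(=O)C1=C(C)N/C(=C/c2cc(C)n(-c3ccc(Br)cc3)c2C)C1=O`, gives 2.1 ug/mL.
Compound 2, `CCOC(=O)C1=C(C)N/C(=C/c2cc(C)n(-c3cc(OC)c(OC)c(OO)c3)c2C)C1=O`, gives 3.1 ug/mL.

Only these two numbers exist so far. Compound 1 has the lowest of the two, but compound 2 sits only a little higher, and that gap lies within the scatter of repeated measurements, so the two values cannot be ordered with confidence. Among the measured compounds shown here, no pair of measured compounds differs in just one place, so no single change has yet been tied to a shift in this assay.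

Compound 3, `CCOC(=O)C1=C(C)N/C(=C/c2cc(C)n(-c3cccnc3)c2C)C1=O`, has not been measured. It differs from compound 1 in one place: pyridin-3-yl in place of 4-bromophenyl on an aromatic nitrogen. For the measured compounds named here, with no measured step of this kind to lean on, the expectation for compound 3 is a modest rise in this assay, somewhat beyond the scatter, as the estimated step of a 3.8-fold higher number from compound 1 to compound 3 (0.58 log units; beyond the scatter) shows. For compound 3 the estimated value is 8 ug/mL, with a range from 2.5 ug/mL to 25 ug/mL.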

Compound 3, solubility: 25 ug/mL
Compound 3: the middle estimate sits 3.1-fold (0.49 log units) below what was measured, and the stated range covers the measured number.
By their numbers in this assay, from the lowest: compounds 1 and 2 (each within the scatter of the next); then compound 3.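

In this assay, the group on the aromatic nitrogen proves able to move the number a long way: pyridin-3-yl in place of 4-bromophenyl gives a 12-fold higher number from compound 1 to compound 3 (1.08 log units; beyond the scatter), a large step and the first one tied to a single change. The swap replaces a carbon-only ring bearing bromine with a ring holding one nitrogen, a hydrogen-bond acceptor, and neither group carries a net charge. Nothing available here explains why the step is so large.

Still open, as far as these compounds go, is whether the step follows the loss of bromine or the arrival of the ring nitrogen, a question that a plain phenyl group at this position could help separate. Also open, from the compounds shown here alone, is how an amine or a carboxylic acid on this ring would change the number.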